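Swapping a ring-bearing group for propanoylamino on compound 3

A few compounds are considered here, and "the series" means these few. Any claim that something is new, unique, unknown or untested is made for them only; others in the source may bear on it.

Measured in a physicochemical assay for solubility, read by LC-MS, in phosphate buffer, with a stated time of 24 h, at pH 6.8; a higher number here means a more soluble compound, a lower number a less soluble compound:
- compound 1 `C[C@@H](c1ccc(NC(=O)N2CC(c3cccnc3)C2)cc1)N1Cc2ccccc2C1=O` gives 130000 nM
- compound 2 `C[C@H](NC(=O)c1ncccn1)c1ccc(NC(=O)N2CC(c3cccnc3)C2)cc1` gives 930000 nM
- compound 3 `C[C@@H](c1ccc(NC(=O)N2CC(c3ccc(N)nc3)C2)cc1)N1Cc2ccccc2C1=O` gives 220000 nM

Compound 2 holds the highest of these numbers. Compound 3 cannot be told apart from compound 1, since the amino group adds only a 1.7-fold higher number from compound 1 to compound 3 (0.23 log units; within the scatter).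

The next compound, compound 4 `CCC(=O)N[C@@H](C)c1ccc(NC(=O)N2CC(c3ccc(N)nc3)C2)cc1`, changes compound 3 in one place: a group of 5 heavy atoms (3 carbon, 1 nitrogen, 1 oxygen; no ring) in place of a group of 10 heavy atoms (8 carbon, 1 nitrogen, 1 oxygen; one five-membered non-aromatic ring with 1 hetero atom, one six-membered aromatic ring of carbon only), on a saturated chain carbon bound to an aromatic carbon and a saturated chain carbon. The group that enters is propanoylamino.

The most useful guide is a 7.2-fold higher number from compound 1 to compound 2 (0.85 log units; beyond the scatter). In that step the same group of 10 heavy atoms leaves, on the same saturated chain carbon, and the number in this assay goes up beyond the scatter. The match is imperfect, however. Among the compounds with values here, the group entering compound 2 still holds a six-membered aromatic ring, while propanoylamino has no ring, and no measured compound shows this exact swap. The amino step gives no reason to expect that compound 3 will respond differently from compound 1, but that is an expectation and remains untested.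

A rise of similar or slightly smaller size is therefore expected, and the estimated step is a 4.1-fold higher number from compound 3 to compound 4 (0.61 log units; beyond the scatter).

Compound 4 is expected to give about 900000 nM, with an estimated range of 350000 nM to 2000000 nM.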

Compound 4, solubility: 760000 nM
Compound 4: middle estimate off by 1.2-fold (0.07 log units), on the high side; the range from low to high includes it.
By their numbers in this assay, from the lowest: compounds 1 and 3 (each within the scatter of the next); then compounds 4 and 2 (each within the scatter of the next).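

Compound 4 shows that the group entering on this saturated chain carbon does not need a ring for the number to rise: propanoylamino has none, yet the change gives a 3.5-fold higher number from compound 3 to compound 4 (0.54 log units; beyond the scatter) in this assay. Within the data shown here, until now, the only step at this position was a 7.2-fold higher number from compound 1 to compound 2 (0.85 log units; beyond the scatter), in which the entering group kept a six-membered aromatic ring and the compounds lacked the amino group. The same group of 10 heavy atoms has now left in two different settings, and both steps lie beyond the scatter, though two steps are too few to make a general rule, and nothing measured here says why the number rises.

Going by these compounds, it remains open whether the rise follows from losing the group of 10 heavy atoms or from what takes its place, and a free amine on the same carbon, or a longer chain such as butanoylamino, would help separate the two. Also open, on these data alone, is whether propanoylamino gives a similar step on compound 1, which lacks the amino group.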